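Swapping one methyl for a methoxy on compound 2

The source may report more compounds than this note shows. Statements on the series, on what has been measured and on what is new or still open speak of the compounds shown alone.

Compound 1 (`COc1ccc(S(=O)(=O)Oc2ccccc2/C=C(\C#N)C(=O)Nc2nnc(-c3cccs3)s2)cc1`) gives 76%
Compound 2 (`Cc1ccc(Cc2nnc(NC(=O)/C(C#N)=C/c3ccccc3OS(=O)(=O)c3ccc(C)cc3)s2)cc1`) gives 66%

Both numbers come from a functional assay on RS4-11 cells (Homo sapiens) for inhibition, read by CCK-8 assay, with a stated time of 48 h, tested at 20 uM (a lower number here means less inhibition of growth, a higher number more inhibition of growth at the concentration tested), and lie within the usual scatter of each other. Compound 2 (66%) therefore cannot be told apart from compound 1 (76%). Compound 3 (`COc1ccc(S(=O)(=O)Oc2ccccc2/C=C(\C#N)C(=O)Nc2nnc(Cc3ccc(C)cc3)s2)cc1`) keeps all of compound 2 except for one change: methoxy in place of methyl on an aromatic carbon, para to a large group (methoxy in place of methyl on an aromatic carbon). Compound 1 also carries the (4-methoxyphenyl)sulfonyl group, but it differs from compound 2 elsewhere as well. For the measured compounds named here, no measured pair shows this change alone, so the expectation is weakly founded. The expected result is a number 5 percentage points higher from compound 2 to compound 3 (within the scatter) (a small rise, with no move beyond the scatter expected). Compound 3 is estimated at 71% (expected range 56% to 86%).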

Compound 3, percent growth inhibition at one concentration: 79%
Compound 3: middle estimate off by 8 percentage points, on the low side; the measured number falls inside the stated range.
By their numbers in this assay, from the lowest: compounds 2, 1 and 3 (each within the scatter of the next, the first and the last beyond it).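

For the compounds shown here, replacing methyl with methoxy on an aromatic carbon, para to a large group, gives a number 13 percentage points higher from compound 2 to compound 3 (beyond the scatter) in this assay, and this is the first pair to show that change on its own. With the (4-methoxyphenyl)sulfonyl group held constant, 4-methylbenzyl in place of thiophen-2-yl gives a number 3 percentage points higher from compound 1 to compound 3 (within the scatter), so these two groups cannot be told apart in this read-out. Nothing available here accounts for the rise seen with methoxy.

From the compounds shown here alone, this change has been read on only one background, so it remains open whether a compound matching compound 1 but carrying methyl would also give a lower number. Also open, going by these compounds, is how a chlorine atom, an ethoxy group or a dimethylamino group would behave at this same place on the ring.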